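The source may report more compounds than this note shows. Statements on the series, on what has been measured and on what is new or still open speak of the compounds shown alone.

Compound 1 `CN(C[C@H]1Cc2c(cccc2N2CCN(C3CC3)CC2)CN1)[C@H]1CCCc2cccnc21` gives 15.5% in an ADME assay on microsomes from liver (Homo sapiens) for metabolic stability, read by LC-MS, with a stated time of 10 min (on this read-out higher numbers stand for a more stable compound and lower numbers for a less stable compound), the lowest of the three measured numbers; compound 2 `CN(C[C@H]1Cc2c(cccc2N2CCN3CCC[C@@H]3C2)CN1)[C@H]1CCCc2cccnc21` gives 52.2% and compound 3 `CN(C[C@H]1Cc2c(cccc2N2CCNC(C)(C)C2)CN1)[C@H]1CCCc2cccnc21` gives 100%. Compound 4 `CN(C[C@H]1Cc2c(cccc2N2CCN(c3ccccn3)CC2)CN1)[C@H]1CCCc2cccnc21` differs from compound 1 by pyridin-2-yl in place of cyclopropyl on an amine nitrogen in a ring. The two measured steps that start from compound 1 also alter the group on the aromatic carbon: a number 36.7 percentage points higher from compound 1 to compound 2 (beyond the scatter) and a number 84.5 percentage points higher from compound 1 to compound 3 (beyond the scatter), both large and both upward. Compound 4 alters only the group on the amine nitrogen within that ring, a smaller change than either of those, and the rise expected for compound 4 is accordingly more modest, estimated as a number 24.5 percentage points higher from compound 1 to compound 4 (beyond the scatter). Compound 4 is therefore estimated at 40%, with a range from 15% to 75%.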

Compound 4, percent of the compound remaining: 27.4%
For compound 4 the middle estimate is 12.6 percentage points above the measured one; measured number inside the range.
By their numbers in this assay, from the lowest: compound 1; then compound 4; then compound 2; then compound 3.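

With the rest of compound 1 unchanged, placing pyridin-2-yl instead of cyclopropyl on the amine nitrogen in the ring gives a number 11.9 percentage points higher from compound 1 to compound 4 (beyond the scatter) in this assay. Unlike the earlier steps, which replaced the whole group on the aromatic carbon, this shows that changing the nitrogen substituent alone can shift the read-out, though only modestly. Nothing available here explains this rise. Going by these compounds, it remains open whether phenyl, which lacks the pyridine ring nitrogen, would behave like pyridin-2-yl. On these data alone, how a small group such as methyl or acetyl would fare on this nitrogen is also open.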